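Furanylmethyl ester of an iridoid glucoside: expected antiproliferative activity

A few compounds are considered here, and "the series" means these few. Any claim that something is new, unique, unknown or untested is made for them only; others in the source may bear on it.

The account concerns compound 1 `C/C=C1/[C@H](O[C@@H]2O[C@H](CO)[C@@H](O)[C@H](O)[C@H]2O)OC=C(C(=O)OC)[C@H]1CC(=O)OCCc1ccc(O)cc1`, an iridoid glucoside bearing a 2-(4-hydroxyphenyl)ethyl ester. In a functional assay on SK-BR-3 cells (Homo sapiens) for antiproliferative activity, read by MTT assay, with a stated time of 72 h (a lower number here means a stronger inhibitor, a higher number a weaker inhibitor), compound 1 gives only a limit, > 20000 nM, and not a measured number. Two acetylated thioesters stand beside it. Compound 2 `C/C=C1/[C@H](O[C@@H]2O[C@H](COC(C)=O)[C@@H](OC(C)=O)[C@H](OC(C)=O)[C@H]2OC(C)=O)OC=C(C(=O)OC)[C@H]1CC(=O)SCCC` gives in this assay a limit, > 15000 nM. Compound 3 `C/C=C1/[C@H](O[C@@H]2O[C@H](COC(C)=O)[C@@H](OC(C)=O)[C@H](OC(C)=O)[C@H]2OC(C)=O)OC=C(C(=O)OC)[C@H]1CC(=O)SCCc1ccccc1` likewise gives in this assay a limit, > 15000 nM. Among the measured compounds shown here, the one step among them, a step that the two limits leave unreadable from compound 2 to compound 3, cannot be read because the limit of > 15000 nM in this assay, at which 2 of the 3 values shown sit, holds both of its ends. For the measured compounds named here, compound 1 itself sits at the limit of > 20000 nM in this assay, at which 1 of the 3 values shown sits, so no measured step is available at all.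

The change now followed leads to compound 4 `C/C=C1/[C@H](O[C@@H]2O[C@H](CO)[C@@H](O)[C@H](O)[C@H]2O)OC=C(C(=O)OC)[C@H]1CC(=O)OCc1ccco1`: furan-2-yl in place of 4-hydroxybenzyl on a saturated chain carbon bound to an oxygen next to a carbonyl group. Going by the values given here, no measured step bears on this replacement; the step from compound 2 to compound 3 concerns a different position and is in any case unreadable. Compound 4 is therefore expected to remain at or near the limit, with a step that the limit leaves unreadable from compound 1 to compound 4 estimated as no more than the scatter. The estimate for compound 4 in this assay is 25000 nM, within 8000 nM to 60000 nM.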

Compound 4, half-maximal inhibitory concentration: > 15000 nM
Compound 4: only a limit was reported; the forecaster's own chance of this, stated with the estimate: 80%; the middle value is on the limit's open side.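

Compound 1 and compound 4 each give only a limit in this assay, so the step between them cannot be read. The compounds shown leave open which side chain on the shared core, if any, would give a number rather than a limit in this assay.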